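Growing the branch on the amide nitrogen

The source may hold more compounds than are shown below. What is called first, only, known or untested is meant among the compounds shown, and "the series" means these compounds.

Two measured compounds share a core and differ only in the group on the amide-type nitrogen. Compound 1 `Cc1ccc(OCC(=O)N(C)Cc2cccs2)cc1` carries a methyl there and in an assay on HEK293 cells for agonist activity at transient receptor potential cation channel subfamily M member 8 (Homo sapiens), read by fluorescence and calcium flux, with a stated time of 15 min (a higher number here means that more compound is needed for the effect, a lower number that less compound is needed), compound 1 gives 400 nM. Compound 2 `Cc1ccc(OCC(=O)N(Cc2cccs2)C(C)C)cc1` carries an isopropyl instead and in this assay compound 2 gives 70 nM, the lowest of the two numbers; the step of a 5.7-fold lower number from compound 1 to compound 2 (0.76 log units; beyond the scatter) lies beyond the scatter.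

Compound 3 `Cc1ccc(OCC(=O)N(Cc2cccs2)C(C)(C)C)cc1` is the next member and has not yet been measured. It differs from compound 2 by methyl in place of hydrogen on a saturated chain carbon bound to an amide-type nitrogen and two saturated chain carbons, so that the branch grows once more in the same direction as between compound 1 and compound 2.

Among the compounds with values here, only the step from compound 1 to compound 2 bears on this change, and it was modest in size. Within the data shown here, the data give no second step of this kind, so whether the trend continues cannot be read from them. Compound 3 is therefore expected to give roughly a 1.4-fold lower number from compound 2 to compound 3 (0.15 log units; within the scatter), a smaller change than the one before it. The estimated value for compound 3 in this assay is 50 nM, within a range from 15 nM to 200 nM.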

Compound 3, half-maximal effective concentration: 11000 nM
The estimate for compound 3 lay 220-fold (2.34 log units) below the measured number, outside the stated range (above it).
By their numbers in this assay, from the lowest: compound 2; then compound 1; then compound 3.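

In this assay, the series does not keep moving in one direction as the branch on the amide-type nitrogen grows: methyl in place of hydrogen on a saturated chain carbon bound to an amide-type nitrogen and two saturated chain carbons reverses the earlier gain, with a 160-fold higher number from compound 2 to compound 3 (2.20 log units; beyond the scatter). The loss goes beyond simply undoing that gain, for tert-butyl in place of methyl on the amide-type nitrogen gives a 28-fold higher number from compound 1 to compound 3 (1.44 log units; beyond the scatter), so that the largest branch of the three ends up with the highest number, while isopropyl has the lowest. This position therefore responds sharply to the change from isopropyl to tert-butyl, a change of 1 heavy atom with no hydrogen-bond donor or acceptor and no net charge, and nothing available here accounts for the reversal.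

The compounds shown leave open where the turn lies among other groups on this nitrogen, such as ethyl, cyclopropyl or a longer chain, and whether any of them would give a number lower than that of compound 2. They also leave open whether isopropyl to tert-butyl would produce a similar step on a different core.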